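Swapping Phenyl for Phenoxy at the Chain End

This account rests on a few compounds, and the source may have more. Where it says the series, first, only, none or still open, it means among the compounds named here.

Compound 1 `CC(C)(C)OC(=O)N1CCC[C@H]1COCCCCCCCCC/C=C/c1ccc(-c2ccccc2)cc1` ends in a phenyl group on an aromatic ring. In a functional assay on PANC-1 cells (Homo sapiens) for inhibition, read by XTT assay, with a stated time of 72 h (on this read-out lower numbers stand for stronger inhibition and higher numbers for weaker inhibition), compound 1 gives 80000 nM. Compound 2 `CC(C)(C)OC(=O)N1CCC[C@H]1COCCCCCCCCC/C=C/c1ccc(Oc2ccccc2)cc1` differs from compound 1 only by phenoxy in place of phenyl on an aromatic carbon. In this assay compound 2 reaches the limit of the assay, > 100000 nM, a limit rather than a measured number (the limit of > 100000 nM in this assay, at which 1 of the 3 values shown sits). That change produced an at least 1.2-fold higher number from compound 1 to compound 2 (0.09 log units; that floor lies within the scatter), so its true size is not pinned down, only its direction as a weakening or no change.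

Compound 3 `CC(C)(C)OC(=O)NCC(=O)N1CCC[C@H]1COCCCCCC/C=C/c1ccc(-c2ccccc2)cc1` rests on a different core; the difference between the core of compound 1 and the core of compound 3 is not broken down here. In this assay compound 3 gives 66700 nM, which lies within the usual scatter of the value of compound 1, so the two cores cannot be told apart on this read-out.

Compound 4 `CC(C)(C)OC(=O)NCC(=O)N1CCC[C@H]1COCCCCCC/C=C/c1ccc(Oc2ccccc2)cc1` has not yet been measured. Going by the values given here, it differs from compound 3 by phenoxy in place of phenyl on an aromatic carbon, the same change as the one from compound 1 to compound 2. The step from compound 3 to compound 4 is expected to be a 1.6-fold higher number from compound 3 to compound 4 (0.22 log units; within the scatter), because the earlier instance of this change gave an at least 1.2-fold higher number from compound 1 to compound 2 (0.09 log units; that floor lies within the scatter) and compound 3 starts from a value close to that of compound 1. Compound 4 is therefore expected to give about 110000 nM, plausibly between 55000 nM and 250000 nM, with a real chance that only a limit is reported.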

Compound 4, half-maximal inhibitory concentration: 63300 nM
Compound 4: middle estimate off by 1.7-fold (0.24 log units), on the high side; low and high end bracket the measured number.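

On the core of compound 3, phenoxy in place of phenyl on an aromatic carbon gives a 1.1-fold lower number from compound 3 to compound 4 (0.02 log units; within the scatter) in this assay, so compound 3 and compound 4 cannot be told apart on this read-out. On the core of compound 1, the same swap can be read only in part: compound 2 gives > 100000 nM, which is a limit and not a number. The two results do not contradict each other, but they do not show that the change has the same size on both cores, and they show only that no difference between the cores can be established: the same change on two cores in this assay, an at least 1.2-fold higher number (0.09 log units; that floor lies within the scatter) from compound 1 to compound 2 and a 1.1-fold lower number (0.02 log units; within the scatter) from compound 3 to compound 4; the limit leaves it open whether they differ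

The compounds shown leave open whether an amine or a carboxylic acid in place of phenoxy would give a number that stands clear of the usual scatter. They also leave open how the phenoxy swap would behave on a core with a longer chain, and whether it would have any readable effect on a compound whose starting number lay much lower in this assay.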